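Compound 4 in the furan-bearing ester series

The compounds below may be only part of what the source reports. "The series", "measured", "known", "first", "only" and "open" are said of these compounds alone.

Measured in a functional assay on MDA-MB-231 cells (Homo sapiens) for cytotoxicity, read by MTT assay, with a stated time of 48 h; a higher number here means a weaker inhibitor, a lower number a stronger inhibitor:
- compound 1 `C=C1CC[C@@H]2[C@](C)(CO)[C@H](O)CC[C@@]2(C)[C@@H]1CCc1ccoc1`: > 100000 nM, a limit
- compound 2 `C=C1CC[C@@H]2[C@](C)(COC(=O)CC)[C@H](OC(=O)CC)CC[C@@]2(C)[C@@H]1CCc1ccoc1`: 40400 nM
- compound 3 `C=C1CC[C@@H]2[C@](C)(COC(=O)COc3ccccc3)[C@H](O)CC[C@@]2(C)[C@@H]1CCc1ccoc1`: 35000 nM

The entry for compound 1 is a limit: the limit of > 100000 nM in this assay, at which 1 of the 3 values shown sits. Going by the values given here, compound 2 at 40400 nM and compound 3 at 35000 nM lie within the scatter of each other, and they are the only two numbers so far.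

The next change leads to compound 4 `C=C1CC[C@@H]2[C@](C)(COC(=O)c3ccc([N+](=O)[O-])cc3)[C@H](O)CC[C@@]2(C)[C@@H]1CCc1ccoc1`, with 4-nitrophenyl in place of phenoxymethyl on a carbonyl carbon.

Among the compounds with values here, one measured step bears on this: an at least 2.8-fold lower number from compound 1 to compound 3 (0.45 log units; beyond the scatter). That step adds the acyl group to a free hydroxyl and does not exchange one acyl group for another, so it sets no size for the present change. With no such exchange measured, the expectation stays anchored on compound 3 at 35000 nM.

No shift beyond the scatter is expected, and the estimated step is a 1.2-fold lower number from compound 3 to compound 4 (0.07 log units; within the scatter). The estimate for compound 4 is 30000 nM, with an expected range of 10000 nM to 85000 nM.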

Compound 4, half-maximal inhibitory concentration: 37500 nM
Beside the measured number, compound 4's estimate is 1.3-fold (0.10 log units) below it; low and high end bracket the measured number.
By their numbers in this assay, from the lowest: compounds 3, 4 and 2 (each within the scatter of the next). At a limit, above all of these: compound 1.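

In this assay, going by these compounds alone, this is the first exchange of one acyl group for another on this carbonyl carbon, and it gives a 1.1-fold higher number from compound 3 to compound 4 (0.03 log units; within the scatter), so 4-nitrophenyl and phenoxymethyl cannot be told apart here. Placing a second, different acyl group on the free hydroxyl repeats the gain seen with (phenoxymethyl)carbonyl, with (4-nitrophenyl)carbonyl giving an at least 2.6-fold lower number from compound 1 to compound 4 (0.42 log units; beyond the scatter). Compound 1 is a limit and not a number, so that step has no upper size: the limit of > 100000 nM in this assay, at which 1 of the 4 values shown sits.

Within the data shown here, whether any group on this carbonyl carbon can move the number beyond the scatter stays open, since only two such groups can be compared directly. An amine or a carboxylic acid on the aromatic ring, or a longer alkyl chain in place of 4-nitrophenyl, would test this.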